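Moving a fluorine on the pendant phenyl ring

A few compounds are considered here, and "the series" means these few. Any claim that something is new, unique, unknown or untested is made for them only; others in the source may bear on it.

Compound 1 `COc1cc2c(Oc3ccc(NC(=O)c4cc(-c5ccc(F)cc5)ccn4)cc3F)ccnc2cc1OCCCN1CCCCC1` gives 250 nM in a functional assay on NCI-H460 cells (Homo sapiens) for cytotoxicity, read by MTT assay, with a stated time of 72 h; a lower number here means a stronger inhibitor, a higher number a weaker inhibitor. Compound 2 `COc1cc2c(Oc3ccc(NC(=O)c4cc(-c5ccccc5F)ccn4)cc3F)ccnc2cc1OCCCN1CCCCC1` carries the change 2-fluorophenyl in place of 4-fluorophenyl on an aromatic carbon and gives 130 nM, a step of a 1.9-fold lower number from compound 1 to compound 2 (0.28 log units; within the scatter). Compound 3 `COc1cc2c(Oc3ccc(NC(=O)c4cc(-c5ccc(F)cc5)ccn4)cc3F)ccnc2cc1OCCCN1CCCC1` differs from compound 1 by pyrrolidin-1-yl in place of piperidin-1-yl on a saturated chain carbon, three bonds along the chain from an oxygen on an aromatic ring, and in this assay compound 3 gives 370 nM, a step of a 1.5-fold higher number from compound 1 to compound 3 (0.17 log units; within the scatter). Compound 4 `COc1cc2c(Oc3ccc(NC(=O)c4cc(-c5ccccc5F)ccn4)cc3F)ccnc2cc1OCCCN1CCCC1` is the partner of compound 3 for the same change, (2-fluorophenyl in place of 4-fluorophenyl on an aromatic carbon); the two cores differ by pyrrolidin-1-yl in place of piperidin-1-yl on a saturated chain carbon, three bonds along the chain from an oxygen on an aromatic ring, and the place of the change is the same in both pairs. He expects a step of a 1.9-fold lower number from compound 3 to compound 4 (0.27 log units; within the scatter) from compound 3 to compound 4, resting on the step of a 1.9-fold lower number from compound 1 to compound 2 (0.28 log units; within the scatter) seen in the other pair. Compound 4 is therefore estimated at 200 nM, between 100 nM and 400 nM.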

Compound 4, half-maximal inhibitory concentration: 140 nM
Beside the measured number, compound 4's estimate is 1.4-fold (0.15 log units) above it, and the stated range covers the measured number.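

In this assay, 2-fluorophenyl in place of 4-fluorophenyl gives a 2.6-fold lower number from compound 3 to compound 4 (0.42 log units; beyond the scatter), and this agrees with the same change on the core of compound 1: the same change on two cores in this assay, a 1.9-fold lower number (0.28 log units; within the scatter) from compound 1 to compound 2 and a 2.6-fold lower number (0.42 log units; beyond the scatter) from compound 3 to compound 4, 1.4-fold (0.14 log units) apart, within the scatter of two such steps. Pyrrolidin-1-yl in place of piperidin-1-yl gives a 1.1-fold higher number from compound 2 to compound 4 (0.03 log units; within the scatter), and this change also carries from one core to the other within the scatter: the same change on two cores in this assay, a 1.5-fold higher number (0.17 log units; within the scatter) from compound 1 to compound 3 and a 1.1-fold higher number (0.03 log units; within the scatter) from compound 2 to compound 4, 1.4-fold (0.14 log units) apart, within the scatter of two such steps. These four compounds show agreement across a single pair of cores only, so they do not show that either change would carry to any other core.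

The compounds shown leave open how a morpholine in place of the piperidin-1-yl group would compare. They also leave open how a chlorine in place of the fluorine would compare.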